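Amide to urea on the dichloropyridine side

The source may hold more compounds than are shown below. What is called first, only, known or untested is meant among the compounds shown, and "the series" means these compounds.

Measured compounds:
Compound 1 `Cc1cc(CO)nc(NNC(=O)Nc2cc(Cl)nc(Cl)c2)c1`: > 23000 nM
Compound 2 `Cc1cc(NNC(=O)Nc2cc(Cl)nc(Cl)c2)ncc1-c1cnn(C)c1`: > 23000 nM
Compound 3 `Cc1cc(CNC(=O)c2cc(Cl)nc(Cl)c2)ncc1-c1cn(C)nc1C`: < 1700 nM

Three compounds have been run in a functional assay on CHO cells for agonist activity at sphingosine 1-phosphate receptor 2 (Homo sapiens), read by fluorescence and calcium flux, with a stated time of 3 min; a lower number here means a stronger inhibitor, a higher number a weaker inhibitor. Compound 1 gives > 23000 nM, which is a limit of the assay and not a number. Compound 2 likewise gives > 23000 nM, again a limit. Compound 3 gives < 1700 nM, also a limit, and so compound 3 stands at the limit of < 1700 nM in this assay, at which 1 of the 3 values shown sits, while the other two sit at the limit of > 23000 nM in this assay, at which 2 of the 3 values shown sit. For the measured compounds named here, compound 3 is thus the only one of the three to return a value at the active end of this assay, though no step between any pair is given, since each pair differs in more than one place.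

Compound 4 `Cc1cc(CNC(=O)Nc2cc(Cl)nc(Cl)c2)ncc1-c1cn(C)nc1C` is not yet measured. It differs from compound 3 in one place: (2,6-dichloropyridin-4-yl)amino in place of 2,6-dichloropyridin-4-yl on a carbonyl carbon, turning the amide of compound 3 into a urea. Going by the values given here, no measured step of this kind is available, so the size of the change is uncertain. Compound 4 is expected to lose some activity relative to compound 3, with an expected step of an at least 2.3-fold higher number from compound 3 to compound 4 (0.37 log units; beyond the scatter), though the result may still stay within the scatter. Compound 4 is estimated at 4000 nM, in the range 600 nM to 25000 nM.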

Compound 4, half-maximal inhibitory concentration: 3500 nM
The estimate for compound 4 lay 1.1-fold (0.06 log units) above the measured number; low and high end bracket the measured number.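

For the compounds shown here, compound 3 and compound 4 form the first pair in this set that differs in one place, giving the first direct reading of a change on the carbonyl carbon in this assay: the step is an at least 2.0-fold higher number from compound 3 to compound 4 (0.31 log units; beyond the scatter). Placing (2,6-dichloropyridin-4-yl)amino in place of 2,6-dichloropyridin-4-yl on that carbon turns the amide into a urea and weakens the compound, yet compound 4 still returns a measured number, 3500 nM. The step is a bound and not an exact size because the value of compound 3 is a limit of the assay and not a number: the limit of < 1700 nM in this assay, at which 1 of the 4 values shown sits.

From the compounds shown here alone, the true size of the loss therefore remains open, as does the question of whether it follows the added hydrogen-bond donor or simply the added nitrogen. An N-methyl urea, which would keep the nitrogen without its hydrogen, or a methylene or ether oxygen in the same place would be needed to tell these apart.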